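A few compounds are considered here, and "the series" means these few. Any claim that something is new, unique, unknown or untested is made for them only; others in the source may bear on it.

The series keeps one shared core and varies the aryl group on the carbon with a double bond to nitrogen. In a functional assay on COLO 205 cells (Homo sapiens) for inhibition, read by sulforhodamine B assay, with a stated time of 48 h (on this read-out lower numbers stand for stronger inhibition of growth and higher numbers for weaker inhibition of growth), compound 1 (`O=C(Cc1csc2nc(-c3ccc(Br)cc3)cn12)N/N=C/c1ccccc1`) gives 66100 nM, compound 2 (`O=C(Cc1csc2nc(-c3ccc(Br)cc3)cn12)N/N=C/c1ccc(O)cc1`) gives 43700 nM and compound 3 (`COc1cccc(OC)c1/C=N/NC(=O)Cc1csc2nc(-c3ccc(Br)cc3)cn12`) gives 35500 nM. Compound 3 thus stands level with the other two, as a 1.9-fold lower number from compound 1 to compound 3 (0.27 log units; within the scatter) and a 1.2-fold lower number from compound 2 to compound 3 (0.09 log units; within the scatter) both lie within the scatter.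

The next structure is compound 4 (`O=C(Cc1csc2nc(-c3ccc(Br)cc3)cn12)N/N=C/c1ccc(Cl)cc1Cl`), with 2,4-dichlorophenyl in place of 2,6-dimethoxyphenyl on a carbon with a double bond to nitrogen. All three measured steps bear on this change, since each alters the same aromatic group. Besides the two steps above, there is a 1.5-fold lower number from compound 1 to compound 2 (0.18 log units; within the scatter), for hydroxy in place of hydrogen on an aromatic carbon. None of the three leaves the scatter. Among the compounds with values here, no compound with chlorine on this group has been measured, so the data give no direct guide to this substitution and the range stays wide. No step beyond the scatter is therefore expected in this assay, and no direction is favoured. The estimated change is a 1.1-fold higher number from compound 3 to compound 4 (0.03 log units; within the scatter). For compound 4 the expected value is 38000 nM, with an estimated range of 14000 nM to 95000 nM.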

Compound 4, concentration for 50% growth inhibition: 75900 nM
Compound 4: the middle estimate sits 2.0-fold (0.30 log units) below what was measured; the range from low to high includes it.
By their numbers in this assay, from the lowest: compounds 3, 2, 1 and 4 (each within the scatter of the next, the first and the last beyond it).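

In this assay, the aryl group on the carbon with a double bond to nitrogen now gives its first step beyond the scatter: 2,4-dichlorophenyl in place of 2,6-dimethoxyphenyl gives a 2.1-fold higher number from compound 3 to compound 4 (0.33 log units; beyond the scatter), a modest change. Against the other two groups, 2,4-dichlorophenyl gives no separation, with a 1.7-fold higher number from compound 2 to compound 4 (0.24 log units; within the scatter) for 4-hydroxyphenyl and a 1.1-fold higher number from compound 1 to compound 4 (0.06 log units; within the scatter) for phenyl, so the pair formed by compound 3 and compound 4 is the only one of the four compounds to separate, and only just. Nothing in hand accounts for the separation between these two groups.

The step exchanges two methoxy groups for two chlorine atoms at once, and the compounds shown cannot tell whether losing the one or gaining the other carries it, nor what a single chlorine or a single methoxy group would give on the phenyl ring. Also open, as far as these compounds go, is how far the numbers at this carbon can move with an aryl group bearing an amine or a carboxylic acid, since all four values here lie close together.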